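The source may hold more compounds than are shown below. What is called first, only, known or untested is meant among the compounds shown, and "the series" means these compounds.

Measured compounds in this series:
compound 1 `C[C@@H](O)[C@H](NC(=O)CN(c1nc(Cl)nc2[nH]cnc12)C1CC1)C(=O)O` — 35.9%
compound 2 `CC(C)[C@H](NC(=O)CN(c1nc(Cl)nc2[nH]cnc12)C1CC1)C(=O)OCc1ccccc1` — 51.3%
compound 3 `O=C(O)C[C@H](NC(=O)CN(c1nc(Cl)nc2[nH]cnc12)C1CC1)C(=O)O` — 25.1%

In a functional assay on the whole organism (Tail, strain ICR) with Mus musculus as the target, in the tail flick test, with a stated time of 90 min, at a dose of 25 umol/kg by the oral route (a lower number here means a weaker effect, a higher number a stronger effect of the compound at the dose given), compound 3 stands lowest of the three numbers; compound 1 is the nearest, compound 2 the furthest, and both gaps are beyond the scatter. Compound 4 `O=C(CN(c1nc(Cl)nc2[nH]cnc12)C1CC1)N[C@@H](CO)C(=O)O` is not yet measured. Its difference from compound 3 is hydroxy in place of carboxy on a saturated chain carbon, two bonds along the chain from an amide-type nitrogen and a carbonyl carbon. For the measured compounds named here, the one measured step that bears on this change is a number 10.8 percentage points lower from compound 1 to compound 3 (beyond the scatter), where carboxymethyl replaced 1-hydroxyethyl and the read-out fell modestly. The present change runs in the opposite sense, carboxy leaving and hydroxy entering, so a rise of about that size is expected, that is a number 8.9 percentage points higher from compound 3 to compound 4 (within the scatter). Compound 2 offers no comparable change. Compound 4 is therefore expected to give 34% in this assay, within 22% to 46%.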

Compound 4, a percentage reported as activity, at one dose (the size of the read-out at that dose, not a potency): 43.9%
Compound 4: the middle estimate sits 9.9 percentage points below what was measured; low and high end bracket the measured number.
By their numbers in this assay, from the lowest: compound 3; then compounds 1, 4 and 2 (each within the scatter of the next, the first and the last beyond it).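

In this assay, the change from carboxy to hydroxy on this saturated chain carbon gives a number 18.8 percentage points higher from compound 3 to compound 4 (beyond the scatter), which isolates the carboxy group as the part that matters here, whereas the earlier step also changed the chain. Removing the methyl gives a number 8 percentage points higher from compound 1 to compound 4 (within the scatter), so hydroxymethyl and 1-hydroxyethyl are not told apart at this position. No available evidence accounts for either step.

From the compounds shown here alone, whether an amine or a carboxamide on this chain carbon would match hydroxy remains open. So does the effect of a longer chain carrying hydroxy.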